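The source may hold more compounds than are shown below. What is called first, only, known or untested is meant among the compounds shown, and "the series" means these compounds.

Working notes on the series. Compound 1 `COc1ccc(-c2cc(N3CCC(CNS(N)(=O)=O)CC3)ncn2)cc1`, compound 2 `NS(=O)(=O)NCC1CCN(c2cc(-c3ccc(Cl)cc3)ncn2)CC1`, compound 3 `COc1ccccc1-c1cc(N2CCC(CCNS(N)(=O)=O)CC2)ncn1` and compound 4 `NS(=O)(=O)NCCC1CCN(c2cc(-c3ccccc3Cl)ncn2)CC1` share one core and were followed in a functional assay on M21 cells (Homo sapiens) for antiproliferative activity, read by sulforhodamine B assay, with a stated time of 48 h (a higher number here means a weaker inhibitor of growth, a lower number a stronger inhibitor of growth), which reads growth inhibition.

For compound 1 the result is a limit of the assay, > 100000 nM. Compound 2 gives 50300 nM. Compound 3 gives 96900 nM, and against compound 2 this lies within the usual scatter, so no order between the two is drawn. The change from compound 1 to compound 2 is chloro in place of methoxy on an aromatic carbon, and it carries an at least 1.9-fold lower number from compound 1 to compound 2 (0.29 log units; that floor lies within the scatter); because the limit of > 100000 nM in this assay, at which 1 of the 3 values shown sits, holds for compound 1, only a floor of the step is known, not its true size. How compound 3 differs from compound 1 is not broken down here.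

Compound 4 is not yet measured. It differs from compound 3 by chloro in place of methoxy on an aromatic carbon. This is the same kind of change as that from compound 1 to compound 2, but not the same: in the first pair the place is para to a large group, in the second it is ortho to a large group. Within the data shown here, the step expected from compound 3 to compound 4 in this assay is a 1.9-fold lower number from compound 3 to compound 4 (0.29 log units; within the scatter), resting on compound 2 against compound 1, where an at least 1.9-fold lower number from compound 1 to compound 2 (0.29 log units; that floor lies within the scatter) gives only a floor, and on the shift of the place from para to ortho, for which there is no measured precedent. Compound 4 is therefore estimated at 50000 nM. The expected range for compound 4 runs from 20000 nM to 120000 nM.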

Compound 4, concentration for 50% growth inhibition: 93900 nM
Compound 4: the middle estimate sits 1.9-fold (0.27 log units) below what was measured; measured number inside the range.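

In this assay, the change from 2-methoxyphenyl to 2-chlorophenyl gives a 1.0-fold lower number from compound 3 to compound 4 (0.01 log units; within the scatter), so no order is drawn between these two compounds. Neither step shows an effect of the exchange beyond the scatter, but this does not establish that the exchange is without effect on the core of compound 1, or that the two cores respond alike: the same change on two cores in this assay, an at least 1.9-fold lower number (0.29 log units; that floor lies within the scatter) from compound 1 to compound 2 and a 1.0-fold lower number (0.01 log units; within the scatter) from compound 3 to compound 4; the limit leaves it open whether they differ. Going by these compounds, the result for compound 1 is a limit, so its step has only a floor and its true size remains unknown: the limit of > 100000 nM in this assay, at which 1 of the 4 values shown sits.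

The two pairs differ in their cores and in the place of the exchange, and the compounds shown cannot separate these two differences. Also open, on these data alone, is how growth inhibition would read with an amine or a carboxylic acid in place of chloro on an aromatic carbon ortho to a large group, or with a longer chain carrying the terminal sulfamide on the shared core.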